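This account rests on a few compounds, and the source may have more. Where it says the series, first, only, none or still open, it means among the compounds named here.

Working notes on the series. The shared core carries two aryl groups, one on the core itself and one on the carbonyl of the enone chain. Compound 1 `COc1ccc(C(=O)/C=C/c2cc(-c3cc(OC)c(OC)c(OC)c3)n3nc(-c4ccccc4)cc3n2)cc1` gives 25200 nM in a functional assay on DU-145 cells (Homo sapiens) for antiproliferative activity, read by MTT assay, with a stated time of 24 h; a higher number here means a weaker inhibitor, a lower number a stronger inhibitor. Compound 2 `COc1ccc(-c2cc(/C=C/C(=O)c3ccc(C)cc3)nc3cc(-c4ccccc4)nn23)cc1OC` gives 26800 nM in this assay, a number within the scatter of compound 1. Compound 3 `COc1ccc(C(=O)/C=C/c2cc(-c3ccc(OC)cc3)n3nc(-c4ccccc4)cc3n2)cc1` gives 8500 nM; the step of a 3.0-fold lower number from compound 1 to compound 3 (0.47 log units; beyond the scatter) is the only one in the set that leaves the scatter, so compound 1 sits at the weak end of the three measured numbers, apart from compound 3 only.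

Compound 4 `COc1cc(-c2cc(/C=C/C(=O)c3ccc(C)c(C)c3)nc3cc(-c4ccccc4)nn23)cc(OC)c1OC` has not been measured. From compound 1 the change is 3,4-dimethylphenyl in place of 4-methoxyphenyl on a carbonyl carbon. For the measured compounds named here, no measured step touches the carbonyl aryl alone; compound 2, which carries a methyl-bearing aryl on its carbonyl, differs from compound 1 in two places, and its number and that of compound 1 lie within the scatter of each other. Going by the values given here, the one step beyond the scatter, from compound 1 to compound 3, sits on the other aryl and does not bear on this change. The step of a 1.1-fold lower number from compound 1 to compound 4 (0.06 log units; within the scatter) is therefore expected to stay within the scatter. Compound 4 is estimated at 22000 nM, range 7000 nM to 65000 nM.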

Compound 4, half-maximal inhibitory concentration: 15400 nM
Beside the measured number, compound 4's estimate is 1.4-fold (0.15 log units) above it, within the range that was stated.
By their numbers in this assay, from the lowest: compounds 3, 4, 1 and 2 (each within the scatter of the next, the first and the last beyond it).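

For the compounds shown here, this is the first step that touches the carbonyl aryl alone: 3,4-dimethylphenyl in place of 4-methoxyphenyl on a carbonyl carbon gives a 1.6-fold lower number from compound 1 to compound 4 (0.21 log units; within the scatter) in this assay, so replacing an aryl that carries one hydrogen-bond acceptor with one that carries none is not resolved from the scatter here. Among the single-place steps shown, only the change on the other aryl, a 3.0-fold lower number from compound 1 to compound 3 (0.47 log units; beyond the scatter), lies beyond the scatter. No measurement here accounts for the number of compound 4.

The compounds shown leave open whether the same carbonyl aryl change stays within the scatter when 4-methoxyphenyl, as in compound 3, replaces 3,4,5-trimethoxyphenyl on the other aryl position. They also leave open how an aryl bearing an amine or a carboxylic acid would read at the carbonyl carbon.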